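The compounds below may be only part of what the source reports. "The series", "measured", "known", "first", "only" and "open" are said of these compounds alone.

Measured compounds:

Compound 1 `CCCn1c(=O)c2nc(-c3ccc(C#N)cc3)[nH]c2n(CCC)c1=O`: 4.48 nM
Compound 2 `CCCn1c(=O)c2nc(-c3ccc(C#N)cc3)[nH]c2n(C)c1=O`: 5.95 nM
Compound 3 `CCCn1c(=O)n(C)c(=O)c2[nH]c(-c3cccs3)nc21`: 8.93 nM

In an assay on Cortex for displacement of a labelled ligand from adenosine receptor A1 (Rattus norvegicus) (on this read-out lower numbers stand for stronger inhibition and higher numbers for weaker inhibition), compound 1 gives the lowest of the three numbers, but the gaps to its neighbours are small: compound 2 sits at 5.95 nM and compound 3 at 8.93 nM, both within the usual scatter of compound 1, so no order among the three can be claimed. Going by the values given here, the single one-place step among them, a 1.3-fold higher number from compound 1 to compound 2 (0.12 log units; within the scatter), concerns a chain on a ring nitrogen and says nothing about the group on the carbon of the five-membered ring.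

Compound 4 `CCCn1c(=O)c2nc(CCc3ccccc3)[nH]c2n(CCC)c1=O` differs from compound 1 in exactly that place: phenethyl in place of 4-cyanophenyl on an aromatic carbon. Among the compounds with values here, compound 3 also carries a different group on that carbon and gives a number close to compound 1, but it differs from compound 1 in more than one place, so no measured step directly bears on this change. The expectation is therefore loosely anchored; compound 4 is estimated at 40 nM with a range from 8 nM to 200 nM, which would mean an 8.9-fold higher number from compound 1 to compound 4 (0.95 log units; beyond the scatter).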

Compound 4, inhibition constant: 57.8 nM
For compound 4 the middle estimate is 1.4-fold (0.16 log units) below the measured one; measured number inside the range.
By their numbers in this assay, from the lowest: compounds 1, 2 and 3 (each within the scatter of the next); then compound 4.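

In this assay, going by these compounds alone, the group on the aromatic carbon between two ring nitrogen atoms proves able to shift the number substantially: phenethyl in place of 4-cyanophenyl gives a 13-fold higher number from compound 1 to compound 4 (1.11 log units; beyond the scatter), whereas the only earlier one-place step concerned a chain on a ring nitrogen. The two groups have the same heavy-atom count and each holds one six-membered aromatic ring of carbon only, so that count and ring type do not distinguish them; the change instead removes the nitrile, with its triple bond and hydrogen-bond acceptor, and introduces the chain of phenethyl. No available evidence explains the step.

The nitrile and the chain change together here, so the compounds shown cannot assign the step to either one. Unsubstituted phenyl or 4-cyanophenethyl on that carbon would separate the two changes.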